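The compounds below may be only part of what the source reports. "The series", "measured", "known", "first", "only" and "open" are said of these compounds alone.

Measured so far:
- compound 1, `Cc1nc(N2CCCCC2)c2nnn(-c3ccc(C(C)C)cc3Br)c2n1`: 46 nM
- compound 2, `CCCC(CCC)Nc1nc(C)nc2c1nnn2-c1c(C)cc(C)cc1C`: 4 nM
- compound 3, `CCCC(CCC)Nc1nc(C)nc2c1nnn2-c1ccc(Br)cc1Br`: 0.8 nM

In an in vitro assay on 293-EBNA cells for binding affinity to corticotropin-releasing factor receptor 1 (Homo sapiens) (a higher number here means a weaker inhibitor, a lower number a stronger inhibitor), compound 1 gives 46 nM, the highest of the three numbers; compound 2 gives 4 nM and compound 3 gives 0.8 nM, both clearly lower. Compound 4, `Cc1nc(N2CCCC2)c2nnn(-c3ccc(C(C)C)cc3Br)c2n1`, differs from compound 1 in one place: pyrrolidin-1-yl in place of piperidin-1-yl on an aromatic carbon. Among the compounds with values here, the only measured step, a 5.0-fold lower number from compound 2 to compound 3 (0.70 log units; beyond the scatter), concerns the aromatic group on the ring nitrogen, not the amine on the core, so it does not bear directly on this change; it only shows that a single swap of a substituent can move the number by a modest amount. Within the data shown here, no measured pair here compares two cyclic amines, so the direction of the step cannot be read from the data. A change of one carbon in a ring is expected to produce a small step, a 1.3-fold higher number from compound 1 to compound 4 (0.12 log units; within the scatter), plausibly within the scatter. The expected value for compound 4 in this assay is therefore 60 nM, with a range from 20 nM to 200 nM.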

Compound 4, inhibition constant: 194 nM
For compound 4 the middle estimate is 3.2-fold (0.51 log units) below the measured one; the range from low to high includes it.
By their numbers in this assay, from the lowest: compound 3; then compound 2; then compound 1; then compound 4.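

The size of the cyclic amine on this aromatic carbon matters: with one ring carbon fewer, pyrrolidin-1-yl in place of piperidin-1-yl gives a 4.2-fold higher number from compound 1 to compound 4 (0.63 log units; beyond the scatter) in this assay and so a weaker inhibitor. Within the data shown here, the earlier compounds held no pair of cyclic amines, and this modest step, beyond the usual scatter, is the first sign that this position responds to a change as small as one ring carbon. Nothing available here explains why the five-membered ring gives the weaker inhibitor.

Two ring sizes give a single step rather than a trend, leaving open whether a seven-membered ring such as azepan-1-yl would continue or reverse it. Also open, going by these compounds, is how an open-chain amine such as diethylamino, or morpholin-4-yl with its ring oxygen, would compare on the same core.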